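A few compounds are considered here, and "the series" means these few. Any claim that something is new, unique, unknown or untested is made for them only; others in the source may bear on it.

Compound 1 `C#CCSc1cnc2ccccc2c1[Se]CC#CCCl` gives 3.2 ug/mL in a functional assay on SW707 cells (Homo sapiens) for antiproliferative activity, with a stated time of 72 h; on this read-out lower numbers stand for stronger inhibition and higher numbers for weaker inhibition. Compound 2 `CSc1cnc2ccccc2c1[Se]CC#CCCl` gives 3.2 ug/mL in this assay; the change hydrogen in place of ethynyl on a saturated chain carbon bound to a sulfur left the read-out at no change at the digits printed from compound 1 to compound 2 (within the scatter). Compound 3 `C#CCSc1cnc2ccccc2c1SCC#CCCl` gives 12.9 ug/mL in this assay; its core differs from the core of compound 1 by a group of 6 heavy atoms (4 carbon, 1 sulfur, 1 chlorine; no ring) in place of a group of 6 heavy atoms (4 carbon, 1 chlorine, 1 selenium; no ring), on an aromatic carbon, and the step is a 4.0-fold higher number from compound 1 to compound 3 (0.61 log units; beyond the scatter). Compound 4 `CSc1cnc2ccccc2c1SCC#CCCl` has not been measured in this assay. It differs from compound 3 by hydrogen in place of ethynyl on a saturated chain carbon bound to a sulfur, the same change as from compound 1 to compound 2, with the place described in the same words. For compound 4 the expected step of no change at the digits printed from compound 3 to compound 4 (within the scatter) is set at essentially no change, because the same change gave no change at the digits printed from compound 1 to compound 2 (within the scatter). Compound 4 is therefore estimated at 12.9 ug/mL, with an expected range from 6.5 ug/mL to 26 ug/mL.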

Compound 4, concentration for 50% inhibition: 3.7 ug/mL
For compound 4 the middle estimate is 3.5-fold (0.54 log units) above the measured one; the whole stated range lies above it.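

In this assay, propargyl to methyl on the sulfur gives a 3.5-fold lower number from compound 3 to compound 4 (0.54 log units; beyond the scatter), so the result of this change does not carry unchanged from the core of compound 1 to the core of compound 3: the same change on two cores in this assay, no change at the digits printed (within the scatter) from compound 1 to compound 2 and a 3.5-fold lower number (0.54 log units; beyond the scatter) from compound 3 to compound 4, 3.5-fold (0.54 log units) apart, beyond the scatter of two such steps

The selenium-to-sulfur exchange in the chlorine-bearing group likewise reads differently with the methylsulfanyl group, giving a 1.2-fold higher number from compound 2 to compound 4 (0.06 log units; within the scatter): the same change on two cores in this assay, a 4.0-fold higher number (0.61 log units; beyond the scatter) from compound 1 to compound 3 and a 1.2-fold higher number (0.06 log units; within the scatter) from compound 2 to compound 4, 3.5-fold (0.54 log units) apart, beyond the scatter of two such steps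

Both gaps come from the same set of compounds, so they show that the two changes do not add up independently here, but not why, nor whether this extends beyond these compounds.

Open, on these data alone, is how a longer chain or an amine-bearing chain in place of propargyl would read on each core. Also open, as far as these compounds go, is whether a carboxylic acid at that place would show the same dependence on the core.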